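Removing the chloro group from compound 1

The compounds below may be only part of what the source reports. "The series", "measured", "known", "first", "only" and "open" are said of these compounds alone.

Measured compounds:
- compound 1, `CCOC(=O)C(C(=O)OCC)C(CC(=O)C[C@@H]1O[C@H](CO)[C@@H](O)[C@H](O)[C@H]1O)c1ccc(Cl)cc1`, -10%
- compound 2, `O=C(/C=C/c1ccc(Cl)cc1)C[C@@H]1O[C@H](CO)[C@@H](O)[C@H](O)[C@H]1O`, -5.97%
- compound 3, `O=C(/C=C/c1cccc([N+](=O)[O-])c1)C[C@@H]1O[C@H](CO)[C@@H](O)[C@H](O)[C@H]1O`, -10%

Of the compounds shown here, three sharing the same sugar-bearing core have been tested in an assay on isolated protein for inhibition of lysosomal alpha-glucosidase (Rattus norvegicus), tested at 100 uM; a higher number here means more inhibition at the concentration tested (going by the name of the read-out), a lower number less inhibition. Compound 1 gives -10%, level with compound 3 at the digits shown, and together these two are the lowest of the three numbers. Compound 2 gives -5.97%, a number only a few points higher than that of compound 1 and within the scatter; none of the three readings can be ordered against the others.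

Compound 4, `CCOC(=O)C(C(=O)OCC)C(CC(=O)C[C@@H]1O[C@H](CO)[C@@H](O)[C@H](O)[C@H]1O)c1ccccc1`, differs from compound 1 by one change: hydrogen in place of chloro on an aromatic carbon. The change is on an aromatic carbon of a six-membered aromatic ring of carbon only, para to a large group.

Among the compounds with values here, no step between measured compounds exists to guide the expectation. Since compound 1 sits at -10% and all three measured numbers lie within the scatter of each other, the step of a number 2 percentage points higher from compound 1 to compound 4 (within the scatter) is expected to be none beyond the scatter. Compound 4 is estimated to give -8%, between -20% and 5%.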

Compound 4, a percentage reported as inhibition, at one concentration (the size of the read-out at that concentration, not a potency): -45%
The estimate for compound 4 lay 37 percentage points above the measured number; measured number outside the range, below it.
By their numbers in this assay, from the lowest: compound 4; then compounds 1, 3 and 2 (each within the scatter of the next).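

Within the data shown here, the 4-chlorophenyl to phenyl change gives a number 35 percentage points lower from compound 1 to compound 4 (beyond the scatter) in this assay and so provides the first step between compounds differing in one place. It shows that this aromatic carbon, para to a large group, is not indifferent to what it carries, which the three earlier readings, all within the scatter of each other, could not reveal. No measurement shown bears on why hydrogen in place of chloro has this effect.

Going by these compounds, whether another group on this carbon, such as fluoro, methoxy, an amine or a carboxylic acid, would read like compound 1 or like compound 4 remains open. On these data alone, it is also open whether hydrogen in place of chloro on compound 2 would produce a step of similar size.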